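Triazole urea series: halogen swap on the pendant phenyl

A few compounds are considered here, and "the series" means these few. Any claim that something is new, unique, unknown or untested is made for them only; others in the source may bear on it.

Compound 1 `O=C(Nc1cccc(OCc2cn(-c3ccccc3)nn2)c1)Nc1ccc(Cl)c(C(F)(F)F)c1` gives 18400 nM in a toxicity assay on MRC5 cells (Homo sapiens) for inhibition, read by MTT assay, with a stated time of 72 h; a higher number here means a weaker inhibitor, a lower number a stronger inhibitor.
Compound 2 `N#Cc1ccccc1-n1cc(COc2cccc(NC(=O)Nc3ccc(Cl)c(C(F)(F)F)c3)c2)nn1` gives 17500 nM in this assay.
Compound 3 `O=C(Nc1cccc(OCc2cn(-c3cccc(Br)c3)nn2)c1)Nc1ccc(Cl)c(C(F)(F)F)c1` gives 11900 nM in this assay.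

Compound 3 carries the lowest of the three numbers, yet its separations from the others, a 1.5-fold lower number from compound 1 to compound 3 (0.19 log units; within the scatter) and a 1.5-fold lower number from compound 2 to compound 3 (0.17 log units; within the scatter), both sit within the scatter, as does a 1.1-fold lower number from compound 1 to compound 2 (0.02 log units; within the scatter). Compound 4 `O=C(Nc1cccc(OCc2cn(-c3ccc(I)cc3)nn2)c1)Nc1ccc(Cl)c(C(F)(F)F)c1` differs from compound 3 by 4-iodophenyl in place of 3-bromophenyl on an aromatic nitrogen. The two measured steps that arrive at compound 3, bromo in place of hydrogen and 3-bromophenyl in place of 2-cyanophenyl, each stayed within the scatter in this assay, so the present change is likewise expected to give no shift beyond the scatter. Compound 4 is estimated at 12000 nM, with a range from 5000 nM to 28000 nM, which amounts to an expected step of a 1.0-fold higher number from compound 3 to compound 4 (0.00 log units; within the scatter).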

Compound 4, half-maximal inhibitory concentration: 6840 nM
Compound 4: middle estimate off by 1.8-fold (0.24 log units), on the high side; low and high end bracket the measured number.
By their numbers in this assay, from the lowest: compounds 4, 3, 2 and 1 (each within the scatter of the next, the first and the last beyond it).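

Going by these compounds alone, on the aromatic nitrogen, 4-iodophenyl gives the first steps beyond the scatter in this assay, both modest: a 2.7-fold lower number from compound 1 to compound 4 (0.43 log units; beyond the scatter) and a 2.6-fold lower number from compound 2 to compound 4 (0.41 log units; beyond the scatter). The change from 3-bromophenyl stays within the scatter, at a 1.7-fold lower number from compound 3 to compound 4 (0.24 log units; within the scatter), so compound 4 separates from compound 1 and compound 2 but not from compound 3. On these data alone, whether a 4-bromophenyl, a 3-iodophenyl or a phenyl bearing an amine or a carboxylic acid would follow compound 4 remains open, and halogen and ring position stay unseparated in this set. No measurement at hand accounts for these steps.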